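This account rests on a few compounds, and the source may have more. Where it says the series, first, only, none or still open, it means among the compounds named here.

Measured in a functional assay on K562 cells (Homo sapiens) for inhibition, read by trypan blue exclusion, with a stated time of 72 h; a higher number here means a weaker inhibitor, a lower number a stronger inhibitor:
compound 1 `Cn1c(=O)c(C(=O)Nc2ccc(F)cc2F)cc2cnc(Nc3ccc4[nH]ccc4c3)nc21` gives 5000 nM
compound 2 `Cn1c(=O)c(S(=O)(=O)Cc2ccc(F)cc2F)cc2cnc(Nc3ccc4[nH]ccc4c3)nc21` gives 1000 nM
compound 3 `Cn1c(=O)c(S(=O)(=O)Cc2ccc(F)cc2)cc2cnc(Nc3ccc4[nH]ccc4c3)nc21` gives 30000 nM

Of these three, compound 3 has the highest number and is the weakest inhibitor in this assay. Compound 4 `Cn1c(=O)c(C(=O)Nc2ccc(F)cc2)cc2cnc(Nc3ccc4[nH]ccc4c3)nc21` differs from it by one change, (4-fluorophenyl)carbamoyl in place of (4-fluorobenzyl)sulfonyl on an aromatic carbon.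

Going by the values given here, two measured steps bear on this change. The first, a 6.0-fold higher number from compound 1 to compound 3 (0.78 log units; beyond the scatter), is modest and runs the exchange of groups in the opposite direction, with a fluoro group lost along the way. The second, a 30-fold higher number from compound 2 to compound 3 (1.48 log units; beyond the scatter), is large and involves only hydrogen in place of fluoro. Compound 4 lacks that same fluoro group, yet it keeps the carbamoyl link of compound 1. Among the compounds with values here, no carbamoyl pair with and without this fluoro group has been measured, so its effect on compound 4 remains open, and the expectation is correspondingly loose.

The expected change is a 3.0-fold lower number from compound 3 to compound 4 (0.48 log units; beyond the scatter), a modest move toward a lower number, though a result near the level of compound 3 would not be surprising.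

For compound 4 the estimated value is 10000 nM, with an expected range from 2500 nM to 40000 nM in this assay.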

Compound 4, half-maximal inhibitory concentration: 5000 nM
For compound 4 the middle estimate is 2.0-fold (0.30 log units) above the measured one, and the stated range covers the measured number.
By their numbers in this assay, from the lowest: compound 2; then compounds 1 and 4 (each within the scatter of the next); then compound 3.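

In this assay, the exchange of (4-fluorobenzyl)sulfonyl for (4-fluorophenyl)carbamoyl at this aromatic carbon can now be read with no fluoro change attached, and it gives a 6.0-fold lower number from compound 3 to compound 4 (0.78 log units; beyond the scatter). With the additional fluoro group present, the order of the two links is the other way round, since compound 1 gives 5000 nM and compound 2 gives 1000 nM, so the better link at this position depends on the substitution of the aromatic ring it carries. Loss of the fluoro group on the carbamoyl side gives no change at the digits printed from compound 1 to compound 4 (within the scatter), so the steep dependence on this fluoro group seen on the sulfonyl side does not carry over, and its effect depends on the link that holds the ring: the same change on two cores in this assay, a 30-fold higher number (1.48 log units; beyond the scatter) from compound 2 to compound 3 and no change at the digits printed (within the scatter) from compound 1 to compound 4, 30-fold (1.48 log units) apart, beyond the scatter of two such steps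

As far as these compounds go, whether a chloro or methoxy group in place of that fluoro group would separate the two links in the same way remains open. From the compounds shown here alone, it is also open how a urea or a sulfonamide link at this aromatic carbon would compare with the carbamoyl and sulfonyl links, with and without the additional fluoro group.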